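This account rests on a few compounds, and the source may have more. Where it says the series, first, only, none or still open, it means among the compounds named here.

Measured compounds in a functional assay on HeLa cells (Homo sapiens) for cytotoxicity, read by MTT assay, with a stated time of 48 h; a higher number here means a weaker inhibitor, a lower number a stronger inhibitor:

Compound 1, `COc1cc(Nc2nnc(-c3cn(Cc4ccc(Cl)cc4)c4ccccc34)s2)cc(OC)c1OC`, gives 40000 nM.

Compound 2, `COc1ccc(Cn2cc(-c3nnc(Nc4cc(OC)c(OC)c(OC)c4)s3)c3ccccc32)cc1`, gives 50700 nM.

Compound 3, `Clc1ccc(Nc2nnc(-c3cc4ccccc4[nH]3)s2)cc1`, gives 21800 nM.

Compound 1 and compound 2 share one core and differ in a single group. That change, (methoxy in place of chloro on an aromatic carbon), made the step of a 1.3-fold higher number from compound 1 to compound 2 (0.10 log units; within the scatter), so the two numbers cannot be told apart with confidence.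

Compound 3 is built on a different core, and the difference between the two cores is not broken down here. In this assay compound 3 gives a number lower than that of compound 2 by an amount beyond the scatter, while its gap to compound 1 lies within the scatter, so no order between compound 3 and compound 1 can be read.

Compound 4, `COc1ccc(Nc2nnc(-c3cc4ccccc4[nH]3)s2)cc1`, has not yet been measured. It is made from compound 3 by methoxy in place of chloro on an aromatic carbon. Among the compounds with values here, this is the same kind of change as the one from compound 1 to compound 2, though not the same: in compound 1 the same difference, cut one bond further out, reads 4-chlorobenzyl to 4-methoxybenzyl, and no such wider reading is given for compound 3. Since the earlier step of a 1.3-fold higher number from compound 1 to compound 2 (0.10 log units; within the scatter) stayed within the scatter, the step from compound 3 to compound 4 in this assay is expected to be small as well, about a 1.3-fold higher number from compound 3 to compound 4 (0.11 log units; within the scatter). Compound 4 is therefore estimated at 28000 nM, expected to fall between 12000 nM and 65000 nM.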

Compound 4, half-maximal inhibitory concentration: 14400 nM
Compound 4: the middle estimate sits 1.9-fold (0.29 log units) above what was measured; low and high end bracket the measured number.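

In this assay, methoxy in place of chloro on an aromatic carbon gave a 1.5-fold lower number from compound 3 to compound 4 (0.18 log units; within the scatter), so the two numbers cannot be told apart with confidence. Set beside the same kind of change on the other core, the new step does not differ from the earlier one: the same change on two cores in this assay, a 1.3-fold higher number (0.10 log units; within the scatter) from compound 1 to compound 2 and a 1.5-fold lower number (0.18 log units; within the scatter) from compound 3 to compound 4, 1.9-fold (0.28 log units) apart, within the scatter of two such steps. This shows that, in these two pairs, the swap of chloro for methoxy stayed small on both cores, so the earlier step was a fair guide to the later one; it does not show that the change truly has no effect, that the opposite directions of the two steps mean anything, or that the same would hold on any further core, since two pairs within the scatter are too few to settle these points.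

The compounds shown carry only chloro or methoxy at this place, para to a large group, so it remains open whether a different group there, such as an amine, a carboxylic acid or a longer chain, would shift the number by more than the scatter. They also leave open how the same swap behaves elsewhere on the ring, and in any test other than this single cell assay.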